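Moving the methyl on the benzyl group of a flavonol

This account rests on a few compounds, and the source may have more. Where it says the series, first, only, none or still open, it means among the compounds named here.

Compound 3 `Cc1cccc(COc2cc(O)c3c(=O)c(O)c(-c4ccccc4)oc3c2)c1` is the only one of the three measured compounds with an actual number in an ADME assay on Huh-5-2 cells (Homo sapiens) for cytotoxicity, read by WST assay, with a stated time of 3 days (on this read-out lower numbers stand for higher toxicity in this test and higher numbers for lower toxicity in this test), where compound 3 gives 35000 nM. Compound 1 `COc1ccccc1COc1cc(O)c2c(=O)c(O)c(-c3ccccc3)oc2c1` reaches only the limit of > 100000 nM in this assay. Compound 2 `O=c1c(O)c(-c2ccccc2)oc2cc(OCc3cccc(Br)c3)cc(O)c12` likewise reaches only the limit of > 100000 nM. The change to compound 4 `Cc1ccc(COc2cc(O)c3c(=O)c(O)c(-c4ccccc4)oc3c2)cc1` is 4-methylphenyl in place of 3-methylphenyl on a saturated chain carbon bound to an oxygen on an aromatic ring. Among the measured compounds shown here, two measured steps bear on it, both ending at compound 3: an at least 2.8-fold lower number from compound 1 to compound 3 (0.45 log units; beyond the scatter) and an at least 2.8-fold lower number from compound 2 to compound 3 (0.45 log units; beyond the scatter), while the limit of > 100000 nM in this assay, at which 2 of the 3 values shown sit, leaves their full size unknown. For the measured compounds named here, no measured step moves a methyl around the same ring, so compound 4 is expected to stay near compound 3. For compound 4 the expected step is a 1.4-fold higher number from compound 3 to compound 4 (0.15 log units; within the scatter), within the scatter. Compound 4 is estimated at 50000 nM, between 20000 nM and 150000 nM.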

Compound 4, half-maximal cytotoxic concentration: 88000 nM
For compound 4 the middle estimate is 1.8-fold (0.25 log units) below the measured one; measured number inside the range.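

With the same atoms and only the methyl moved on the ring, this assay gives a 2.5-fold higher number from compound 3 to compound 4 (0.40 log units; beyond the scatter), so the methyl's place alone shifts this read-out towards lower toxicity in this test. The other two steps are only floors, an at least 1.1-fold lower number from compound 2 to compound 4 (0.05 log units; that floor lies within the scatter) and an at least 1.1-fold lower number from compound 1 to compound 4 (0.05 log units; that floor lies within the scatter), and their full size stays unknown: the limit of > 100000 nM in this assay, at which 2 of the 4 values shown sit.

On these data alone, what stays open is whether this shift holds for other groups, such as a 4-bromophenyl, and how an amine or a carboxylic acid in place of the methyl would read.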